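Trifluoromethyl in place of nitro: the step to compound 3

A few compounds are considered here, and "the series" means these few. Any claim that something is new, unique, unknown or untested is made for them only; others in the source may bear on it.

For the measured compounds named here, in a functional assay on SMMC-7721 cells (Homo sapiens) for cytotoxicity, read by MTT assay, with a stated time of 24 h (on this read-out lower numbers stand for stronger inhibition and higher numbers for weaker inhibition), compound 1 `O=C1/C(=C/c2cccnc2)CN(S(=O)(=O)c2ccccc2)C/C1=C\c1ccccc1F` gives 19100 nM, and this is the only exact number available. Compound 2 `O=C1/C(=C/c2cccnc2)CN(S(=O)(=O)c2ccc([N+](=O)[O-])cc2)C/C1=C\c1ccccc1F` stands only at a limit, > 20000 nM. From the compounds shown here alone, its true position on the scale therefore stays open. The next compound, compound 3 `O=C1/C(=C/c2cccnc2)CN(S(=O)(=O)c2ccc(C(F)(F)F)cc2)C/C1=C\c1ccccc1F`, keeps the shared core and carries trifluoromethyl in place of nitro on an aromatic carbon, para to a large group (trifluoromethyl in place of nitro on an aromatic carbon). In terms of the whole substituent, 4-nitrophenyl becomes 4-(trifluoromethyl)phenyl. Going by the values given here, one measured step bears on this site, the introduction of nitro in place of hydrogen, which gives an at least 1.0-fold higher number from compound 1 to compound 2 (0.01 log units; that floor lies within the scatter). That step sets only a floor, so it gives no measured size for what a group at this site does. With compound 1 at 19100 nM as the sole numerical anchor, no large move is expected in this assay. The expected change is an at least 1.1-fold lower number from compound 2 to compound 3 (0.04 log units; that floor lies within the scatter), which means no clear shift in either direction. For compound 3 the estimated value is 18000 nM, with an expected range from 8000 nM to 40000 nM.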

Compound 3, half-maximal inhibitory concentration: 7900 nM
Estimate against measurement, compound 3: 2.3-fold (0.36 log units) above, outside the stated range (below it).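

In this assay, trifluoromethyl in place of hydrogen gives a 2.4-fold lower number from compound 1 to compound 3 (0.38 log units; beyond the scatter). For the compounds shown here, this is the first exact step at this site, and it shows that a group here can move the number beyond the scatter, which the floor for nitro in place of hydrogen could not show. Trifluoromethyl in place of nitro gives an at least 2.5-fold lower number from compound 2 to compound 3 (0.40 log units; beyond the scatter), so the two groups do not read alike at this site, although the full size of that step remains unknown. The reading of compound 2 is a limit and not a number, which leaves this step as a floor: the limit of > 20000 nM in this assay, at which 1 of the 3 values shown sits.

With only hydrogen, nitro and trifluoromethyl at this site, the compounds shown leave open whether the lower number is particular to trifluoromethyl or also appears with other groups, such as chlorine, a methyl group, a methoxy group or an amine. They also leave open whether trifluoromethyl would give a step of similar size if the other groups on the shared core were changed.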